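Methoxy to hydroxy on the core of compound 1

The source may report more compounds than this note shows. Statements on the series, on what has been measured and on what is new or still open speak of the compounds shown alone.

The series rests on the core of compound 1 `CCCCOc1ccc(C(=O)n2c(C)c(CC(=O)O)c3cc(OC)ccc32)cc1`. In an assay on isolated protein for binding affinity to prostaglandin E2 receptor EP3 subtype (Mus musculus) (on this read-out higher numbers stand for weaker inhibition and lower numbers for stronger inhibition), compound 1 gives only a limit, > 10000 nM. Compound 2 `CCCCOc1ccc(C(=O)n2c(C)c(CCCCC(=O)O)c3cc(OC)ccc32)cc1` carries 3-carboxypropyl in place of carboxy on a saturated chain carbon bound to an aromatic carbon, and in this assay compound 2 likewise gives only a limit, > 10000 nM. The step that the two limits leave unreadable from compound 1 to compound 2 cannot be read, since both values sit at the limit of > 10000 nM in this assay, at which 2 of the 2 values shown sit. Compound 1 thus stands nowhere but at that limit. The change to compound 3 `CCCCOc1ccc(C(=O)n2c(C)c(CC(=O)O)c3cc(O)ccc32)cc1` is hydrogen in place of methyl on an oxygen on an aromatic ring, that is, methoxy to hydroxy. Going by the values given here, no measured step touches this oxygen, and the one step recorded is unreadable at the limit, so no direction can be set for compound 3 in this assay. The step that the limit leaves unreadable from compound 1 to compound 3 is expected to be small, with compound 3 most likely remaining at the limit. Compound 3 is estimated at 15000 nM, within 3000 nM to 60000 nM.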

Compound 3, inhibition constant: > 10000 nM
Compound 3: a limit, no number; the forecaster's own chance of this, stated with the estimate: 80%; the middle value lies beyond the limit too.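

Compound 3 gives > 10000 nM in this assay, a limit and not a number. No step can be read from compound 1 to compound 3, as both stand at a limit: the limit of > 10000 nM in this assay, at which 3 of the 3 values shown sit.

The compounds shown leave open whether methoxy to hydroxy changes binding at all in this assay.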